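A few compounds are considered here, and "the series" means these few. Any claim that something is new, unique, unknown or untested is made for them only; others in the source may bear on it.

Series notes, cytotoxicity. In a functional assay on J774 cells (Mus musculus) for cytotoxicity, with a stated time of 48 h (on this read-out higher numbers stand for weaker inhibition and lower numbers for stronger inhibition), compound 1 `CC(C)(C)OC(=O)NCC(=O)N1CCC[C@H]1C(=O)N1[C@H](C(=O)OCc2ccccc2)[C@H]1C(=O)OCc1ccccc1` gives > 100000 nM, which is a limit and not a number. Compound 2 `CC(C)(C)OC(=O)NCC(=O)N1CCC[C@@H]1C(=O)N1[C@H](C(=O)OCc2ccccc2)[C@H]1C(=O)OCc1ccccc1` gives > 100000 nM, also a limit. Compound 3 `CCOC(=O)[C@@H]1[C@@H](C(=O)OCC)N1C(=O)[C@H]1CCCN(C(=O)[C@H](CC(C)C)NC(=O)OC(C)(C)C)C1`, which also carries an isobutyl, gives > 100000 nM, again a limit. The series therefore shows only (the limit of > 100000 nM in this assay, at which 3 of the 3 values shown sit), and compound 1 has no measured number to start from.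

Compound 4 `CC(C)C[C@H](NC(=O)OC(C)(C)C)C(=O)N1CCC[C@H]1C(=O)N1[C@H](C(=O)OCc2ccccc2)[C@H]1C(=O)OCc1ccccc1` is still unmeasured. The change from compound 1 is isobutyl in place of hydrogen on a saturated chain carbon bound to an amide-type nitrogen and a carbonyl carbon.

Among the compounds with values here, the only measured step is a step that the two limits leave unreadable from compound 1 to compound 2, and it concerns (the fact that compounds 1 and 2 differ only in the configuration as drawn). It gives no size to carry over, and it does not test the isobutyl change. The expectation therefore rests on the limit of compound 1 at > 100000 nM and the matching limit of compound 3 at > 100000 nM. No step beyond the scatter is expected in this assay, and no direction can be argued from these data. The estimated step is a number no higher from compound 1 to compound 4 (the limit leaves the size open). The value expected for compound 4 is about 100000 nM, with an estimated range from 30000 nM to 200000 nM, and a report as a limit is the likely outcome.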

Compound 4, half-maximal inhibitory concentration: > 125000 nM
Compound 4 ended at the assay's limit; the forecaster's own chance of this, stated with the estimate: 85%; middle value at least 1.2-fold (0.09 log units) away from the limit.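

Compound 1 and compound 4 both stand as limits in this assay, and no step can be read between them. The compounds shown leave open whether isobutyl in place of hydrogen on a saturated chain carbon bound to an amide-type nitrogen and a carbonyl carbon changes the read-out at all; none of them gives a number.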